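The compounds below may be only part of what the source reports. "The series", "measured", "known", "first", "only" and "open" are said of these compounds alone.

Measured so far:
compound 1 `CC(c1ccc2oc(-c3ccccc3)cc2c1)N(O)C(=O)c1ccccc1` — in an assay on RBL cells for inhibition of Polyunsaturated fatty acid 5-lipoxygenase (Rattus norvegicus) (on this read-out higher numbers stand for weaker inhibition and lower numbers for stronger inhibition), compound 1 gives 4830 nM.
compound 2 `CCCCCCCCCCc1cc2cc(C(C)N(O)C(=O)CCCC(=O)OC)ccc2o1` — in this assay compound 2 gives 150 nM.

Compound 1 stands at the highest number of the two, and compound 2 sits well below it, a gap beyond the usual scatter. Among the compounds with values here, no pair of measured compounds differing in a single place is known, so the step to compound 3 `COCC(=O)N(O)C(C)c1ccc2oc(-c3ccccc3)cc2c1` rests on the change itself: methoxymethyl in place of phenyl on a carbonyl carbon. A modest step downward in this assay is expected for compound 3, though it may well stay within the scatter. Compound 3 is estimated at 1500 nM, between 400 nM and 6000 nM. That estimate means an expected step of a 3.2-fold lower number from compound 1 to compound 3 (0.51 log units; beyond the scatter).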

Compound 3, half-maximal inhibitory concentration: 160 nM
For compound 3 the middle estimate is 9.4-fold (0.97 log units) above the measured one; measured number below the stated range.
By their numbers in this assay, from the lowest: compounds 2 and 3 (each within the scatter of the next); then compound 1.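

On the carbonyl carbon, the group held there proves to matter a great deal: in this assay, methoxymethyl in place of phenyl gives a 30-fold lower number from compound 1 to compound 3 (1.48 log units; beyond the scatter), a large step on an otherwise unchanged core. An aromatic ring is therefore not needed on this carbon for the lower number. No measurement bears on why the step is this large.

The change removes the ring and brings in an oxygen together, so the compounds shown leave open which of the two carries the step, and how a plain propyl chain or a dimethylamino group would read on the same carbon.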